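The source may hold more compounds than are shown below. What is called first, only, known or untested is meant among the compounds shown, and "the series" means these compounds.

Measured compounds
compound 1, `O=c1ccoc2cc(OCc3cn(Cc4cccc(F)c4)nn3)ccc12`: in a functional assay on QGY7701 cells (Homo sapiens) for cytotoxicity, read by MTT assay, with a stated time of 48 h (a higher number here means a weaker inhibitor, a lower number a stronger inhibitor), compound 1 gives > 100000 nM, which is a limit of the assay.
compound 2, `O=c1ccoc2cc(OCc3cn(Cc4ccc(Br)cc4)nn3)ccc12`: in this assay compound 2 gives 96400 nM.

Among the compounds with values here, compound 2 carries the only numerical value in the set; the other entry is a limit (the limit of > 100000 nM in this assay, at which 1 of the 2 values shown sits), so compound 2 cannot be placed against any second number. Within the data shown here, the one measured step, an at least 1.0-fold lower number from compound 1 to compound 2 (0.01 log units; that floor lies within the scatter), exchanges the aryl group on the saturated chain carbon bound to the aromatic nitrogen and stays within the scatter.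

Compound 3, `O=c1ccoc2cc(OCc3cn(Cc4ccc([N+](=O)[O-])cc4)nn3)ccc12`, differs from compound 2 by nitro in place of bromo on an aromatic carbon of the same six-membered ring, para to a large group. Among the measured compounds shown here, no measured step involves a nitro group. For the measured compounds named here, the only step that bears on this part of the molecule, from compound 1 to compound 2, moved the read-out by no more than the scatter. The expectation in this assay is therefore a step of no size beyond the scatter, a 1.0-fold lower number from compound 2 to compound 3 (0.01 log units; within the scatter), with a real chance of a limit rather than a number. Compound 3 is estimated at 95000 nM, within 35000 nM to 250000 nM.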

Compound 3, half-maximal inhibitory concentration: > 100000 nM
Compound 3 was reported as a limit (the forecaster's own chance of this, stated with the estimate: 45%); middle value at least 1.0-fold (0.02 log units) from the limit.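

In this assay, as far as these compounds go, nitro in place of bromo on the aromatic carbon para to a large group gives an at least 1.0-fold higher number from compound 2 to compound 3 (0.01 log units; that floor lies within the scatter), so the position has now taken a group other than a halogen without yielding a stronger inhibitor, although the true size of this step stays unknown. In this assay compound 3 gives > 100000 nM, which is a limit of the assay and not a number. The step between compound 1 and compound 3 cannot be read, and compound 2 remains the only compound in the series with a number, the rest of the set sitting at the limit: the limit of > 100000 nM in this assay, at which 2 of the 3 values shown sit.

Still open, from the compounds shown here alone, is whether any group on this aromatic carbon, such as an amine or a carboxylic acid, can give a number clearly below the level of compound 2 and so show that the position matters at all in this cell read-out. Also open, going by these compounds, is whether a longer chain in place of the saturated chain carbon bound to the aromatic nitrogen, or a change on the shared core, would shift the read-out more than any exchange on this aromatic ring.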